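Chloro for hydrogen on a fused purine-like core

This account rests on a few compounds, and the source may have more. Where it says the series, first, only, none or still open, it means among the compounds named here.

Measured so far:
compound 1 `ClCc1ccc(Cn2cnc3c(Cl)ncnc32)cc1`: 2130 nM
compound 2 `ClCc1cccc(Cn2cnc3c(Cl)nc(Cl)nc32)c1`: 3310 nM

Compound 1 gives the lowest of the two numbers in a functional assay on RPMI-8226 cells (Homo sapiens) for cytotoxicity, read by sulforhodamine B assay, with a stated time of 48 h (on this read-out higher numbers stand for weaker inhibition of growth and lower numbers for stronger inhibition of growth), though compound 2 is close to it, with the two values within the usual scatter of each other. Compound 3 `ClCc1ccc(Cn2cnc3c(Cl)nc(Cl)nc32)cc1` has not yet been measured. It differs from compound 1 by a single change: chloro in place of hydrogen on an aromatic carbon. Going by the values given here, no step between two measured compounds isolates this change. Compound 2 carries the same pair of chloro groups on the core and gives 3310 nM, which stands close to compound 1, so the two values alone give no sign of a large shift in either direction. On that basis the step from compound 1 to compound 3 is expected to be small, a 1.2-fold higher number from compound 1 to compound 3 (0.07 log units; within the scatter), not beyond the scatter. Compound 3 is therefore estimated at 2500 nM, with a range from 1000 nM to 6000 nM.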

Compound 3, concentration for 50% growth inhibition: 1740 nM
Estimate against measurement, compound 3: 1.4-fold (0.16 log units) above, within the range that was stated.
By their numbers in this assay, from the lowest: compounds 3, 1 and 2 (each within the scatter of the next).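

In this assay, going by these compounds alone, chloro in place of hydrogen on the aromatic carbon between two ring nitrogen atoms gives a 1.2-fold lower number from compound 1 to compound 3 (0.09 log units; within the scatter) and is the first step that isolates this change. The position therefore carries a chloro group, with one heavy atom where there was only hydrogen, without a shift beyond the scatter in growth inhibition of these cells. Nothing measured here explains the size of this step or ties it to any property of the chloro group.

The compounds shown leave open whether a larger or different group at this position, such as an amine, a methoxy group or a longer chain, would move the number beyond the scatter. They also leave open what replacing the chloromethyl group of compound 3 with a hydroxymethyl group would do.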